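This account rests on a few compounds, and the source may have more. Where it says the series, first, only, none or still open, it means among the compounds named here.

Compound 2 `Cc1cc(C)nc(N(CCNC(C)C)C(=O)N(C)C)c1` stands highest of the two numbers measured in a functional assay on the whole organism (stomach) for inhibition, with Canis familiaris (Canis lupus familiaris) as the target, at a dose of 40 mg/kg by the oral route (a higher number here means a stronger effect of the compound at the dose given, a lower number a weaker effect), giving 42%. For the measured compounds named here, compound 1 `CNCCN(C(=O)N(C)C)c1cc(C)cc(C)n1` gives 20% in this assay, and the single measured step, a number 22 percentage points higher from compound 1 to compound 2 (beyond the scatter), is the only guide to the next change. Compound 3 `Cc1cc(C)nc(N(CCN(C)C)C(=O)N(C)C)c1` differs from compound 2 by dimethylamino in place of isopropylamino on a saturated chain carbon, two bonds along the chain from an amide-type nitrogen. Inhibition is expected to fall somewhat for compound 3, because a number 22 percentage points higher from compound 1 to compound 2 (beyond the scatter) moved upward when the bulkier group replaced methyl, and the reverse direction is now taken, though a tertiary dimethylamino has no measured precedent here. Compound 3 is therefore estimated at 25%, from 8% to 45%, a step of a number 17 percentage points lower from compound 2 to compound 3 (beyond the scatter).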

Compound 3, a percentage reported as inhibition, in the whole organism at one dose (the size of the read-out at that dose, not a potency): 58%
Compound 3: middle estimate off by 33 percentage points, on the low side; measured number outside the range, above it.
By their numbers in this assay, from the lowest: compound 1; then compound 2; then compound 3.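

In this assay, dimethylamino in place of isopropylamino gives a number 16 percentage points higher from compound 2 to compound 3 (beyond the scatter), so the bulkier amine of compound 2 is not the best of the three, and a hydrogen-bond donor on this nitrogen is not required. Adding a methyl in place of hydrogen on the amine nitrogen gives a number 38 percentage points higher from compound 1 to compound 3 (beyond the scatter), a large step from a single added carbon. Nothing measured here explains why this tertiary amine gives the highest number.

Still open, from the compounds shown here alone, is how diethylamino or a pyrrolidine ring would behave at this position. A longer chain leading to the amine is also untested among these compounds.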